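This account rests on a few compounds, and the source may have more. Where it says the series, first, only, none or still open, it means among the compounds named here.

In a physicochemical assay for solubility, read by nephelometry (on this read-out lower numbers stand for lower solubility and higher numbers for higher solubility), compound 2 `CNC(=O)c1cc(CN2C(=O)N(c3ccc(SC(F)(F)F)cc3)C(=O)C2(C)C)ccn1` gives < 0.023 ug/mL, which is a limit of the assay and not a number. Compound 1 `CC1(C)C(=O)N(c2ccc(SC(F)(F)F)cc2)C(=O)N1Cc1ccnc(N2CCCCC2)c1` gives < 0.024 ug/mL, which is also a limit. Among the compounds with values here, the one measured step is a step that the two limits leave unreadable from compound 1 to compound 2, with methylcarbamoyl in place of piperidin-1-yl on an aromatic carbon. Compound 3 `CC(C)Nc1cc(CN2C(=O)N(c3ccc(SC(F)(F)F)cc3)C(=O)C2(C)C)ccn1` has isopropylamino in place of methylcarbamoyl on an aromatic carbon, next to the ring nitrogen (isopropylamino in place of methylcarbamoyl on an aromatic carbon). Within the data shown here, only that measured step bears on this change, and it offers no size to carry over. Neither direction can be argued from it, so no step beyond the scatter is expected in this assay, and another limit is the likeliest report. The expected step is a number no lower from compound 2 to compound 3 (the limit leaves the size open). For compound 3 the estimated solubility is 0.023 ug/mL, with an expected range of 0.008 ug/mL to 0.1 ug/mL.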

Compound 3, solubility: < 0.023 ug/mL
Compound 3: no number, only a limit; the forecaster's own chance of this, stated with the estimate: 70%; the middle value lies on the limit itself.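

Compound 1, compound 2 and compound 3 all give limits and not numbers in this assay, so no step can be read among them. Going by these compounds, the actual solubility of each stays open, as does whether piperidin-1-yl, methylcarbamoyl and isopropylamino differ at all in this assay.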